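The compounds below may be only part of what the source reports. "The series", "measured", "known", "first", "only" and "open" are said of these compounds alone.

Measured so far in a functional assay on the whole organism for inhibition, with Rattus norvegicus as the target, read by paw edema; on this read-out lower numbers stand for an effect already at smaller amounts and higher numbers for an effect only at larger amounts of compound:

compound 1 `O=C(O)c1cc(-n2cccc2)ccc1O` gives 50 mg/kg
compound 2 `O=C(O)c1cc(C2N=NN=N2)ccc1O` gives 110 mg/kg
compound 3 `O=C(O)c1cc(-c2cc[nH]n2)ccc1O` gives > 250 mg/kg

For compound 3 the value is a limit of the assay and not a number (the limit of > 250 mg/kg in this assay, at which 1 of the 3 values shown sits). Compound 1 stands lowest of the three: a 2.2-fold higher number from compound 1 to compound 2 (0.34 log units; beyond the scatter) and an at least 5.0-fold higher number from compound 1 to compound 3 (0.69 log units; beyond the scatter). The remaining step, an at least 2.2-fold higher number from compound 2 to compound 3 (0.35 log units; beyond the scatter), also runs upward, so compound 3 sits at the top of the measured range, with only a limit known.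

Compound 4 `O=C(O)c1cc(-c2cscn2)ccc1O` differs from compound 3 in one place: 1,3-thiazol-4-yl in place of 1H-pyrazol-3-yl on an aromatic carbon. Among the compounds with values here, no measured step replaces either of these rings with a thiazole. Within the data shown here, the steps that bear on it are those into the pyrazole, an at least 5.0-fold higher number from compound 1 to compound 3 (0.69 log units; beyond the scatter) and an at least 2.2-fold higher number from compound 2 to compound 3 (0.35 log units; beyond the scatter), which show that every other five-membered ring measured here gives a lower number than the pyrazole. Leaving the pyrazole for a thiazole is therefore expected to bring the number back down, to a modest step of an at least 2.0-fold lower number from compound 3 to compound 4 (0.31 log units; beyond the scatter). Compound 4 is estimated at 120 mg/kg, with a range from 50 mg/kg to 300 mg/kg, and a real chance that it also stays at the limit.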

Compound 4, dose for half-maximal effect: 95 mg/kg
Beside the measured number, compound 4's estimate is 1.3-fold (0.10 log units) above it; measured number inside the range.
By their numbers in this assay, from the lowest: compounds 1, 4 and 2 (each within the scatter of the next, the first and the last beyond it). At a limit, above all of these: compound 3.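

At the place para to a hydroxy group and meta to a carboxy group, read in this assay, 1,3-thiazol-4-yl in place of 1H-pyrazol-3-yl gives an at least 2.6-fold lower number from compound 3 to compound 4 (0.42 log units; beyond the scatter), so a ring with the same heavy-atom count can leave the top of the measured range. The value of compound 3 is a limit and not a number: the limit of > 250 mg/kg in this assay, at which 1 of the 4 values shown sits.

The thiazole is not separated from the other two rings, with a 1.2-fold lower number from compound 2 to compound 4 (0.06 log units; within the scatter) and a 1.9-fold higher number from compound 1 to compound 4 (0.28 log units; within the scatter), so among the four rings only the pyrazole stands apart.

The change from compound 3 to compound 4 swaps a hydrogen-bond donor for a sulfur atom in one step, and the compounds shown do not tell these two apart. Going by these compounds, how an amine or a phenyl ring would read at this place also stays open.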